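The source may report more compounds than this note shows. Statements on the series, on what has been measured and on what is new or still open speak of the compounds shown alone.

Measured compounds:
- compound 1 `Cc1ccc(C2=NN(c3ccc([N+](=O)[O-])cc3)C(c3cn(-c4ccccc4)nc3-c3ccc(Cl)c(Cl)c3)C2)cc1`: 57.4%
- compound 2 `O=CN1N=C(c2ccc(F)cc2)CC1c1cn(-c2ccccc2)nc1-c1ccc(Cl)c(Cl)c1`: 37.2%

In a functional assay on the whole organism (strain Wistar) for inhibition, with Rattus norvegicus as the target, read by paw edema, with a stated time of 30 min, at a dose of 50 mg/kg by the oral route (a higher number here means more inhibition at the dose given (going by the name of the read-out), a lower number less inhibition), compound 1 gives 57.4%, the higher of the two numbers; compound 2 gives 37.2%, a gap beyond the scatter. The two differ in more than one place, so their numbers only stand side by side. Compound 3 `Cc1ccc(C2=NNC(c3cn(-c4ccccc4)nc3-c3ccc(Cl)c(Cl)c3)C2)cc1` is not yet measured. It differs from compound 1 by hydrogen in place of 4-nitrophenyl on an amine nitrogen in a ring. Among the compounds with values here, no measured pair shows this change. A downward step from compound 1 to compound 3 is expected, larger than the scatter. Compound 3 is estimated at 40% (25% to 55%), an expected step of a number 17.4 percentage points lower from compound 1 to compound 3 (beyond the scatter).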

Compound 3, a percentage reported as inhibition, in the whole organism at one dose (the size of the read-out at that dose, not a potency): 38.3%
Estimate against measurement, compound 3: 1.7 percentage points above; low and high end bracket the measured number.
By their numbers in this assay, from the lowest: compounds 2 and 3 (each within the scatter of the next); then compound 1.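

In this assay, within the data shown here, hydrogen in place of 4-nitrophenyl on the amine nitrogen in the ring gives a number 19.1 percentage points lower from compound 1 to compound 3 (beyond the scatter), the first single-change reading, and shows that inhibition at this dose responds to the group at this position. Compound 3, with only hydrogen there, still gives 38.3%, so inhibition does not depend on having the aryl group. Nothing at hand accounts for the step.

From the compounds shown here alone, whether the step follows the nitro group or the phenyl ring itself remains open; an unsubstituted phenyl on this nitrogen would separate the two.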